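This account rests on a few compounds, and the source may have more. Where it says the series, first, only, none or still open, it means among the compounds named here.

Of the compounds shown here, three have been measured in a functional assay on SK-HEP1 cells (Homo sapiens) for antiproliferative activity, read by sulforhodamine B assay; on this read-out lower numbers stand for stronger inhibition of growth and higher numbers for weaker inhibition of growth. Compound 1 `Cc1ccc(C(=O)Nc2nc3cc(C)cc(C)c3s2)cc1` gives 2.17 ug/mL in this assay. Compound 2 `COc1ccc2sc(NC(=O)c3ccc(C(F)(F)F)cc3)nc2c1` returns only a limit in this assay, namely > 10 ug/mL. Compound 3 `COc1ccccc1NC(=O)Nc1nc2ccc(F)cc2s1` likewise returns only a limit in this assay, namely > 10 ug/mL. Compound 3 thus stands at the limit of > 10 ug/mL in this assay, at which 2 of the 3 values shown sit, and no number is known for it. Within the data shown here, no pair of the measured compounds differs in a single place, so no measured step is available to guide the next change. Compound 4 `O=C(Nc1ccccc1)Nc1nc2ccc(F)cc2s1` has not yet been measured. It differs from compound 3 by hydrogen in place of methoxy on an aromatic carbon. Among the measured compounds shown here, with only a limit for compound 3 and no measured step to draw on, the change a step that the limit leaves unreadable from compound 3 to compound 4 is expected to be small, in no clear direction beyond the scatter. Compound 4 is therefore estimated at 12 ug/mL in this assay, with a range from 4 ug/mL to 40 ug/mL, and it is thought likely that only a limit will again be reported.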

Compound 4, concentration for 50% growth inhibition: > 10 ug/mL
Compound 4 was reported as a limit; the forecaster's own chance of this, stated with the estimate: 70%; the middle value lies beyond the limit too.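

Compound 3 and compound 4 both return only limits, so no step can be read for hydrogen in place of methoxy: the limit of > 10 ug/mL in this assay, at which 3 of the 4 values shown sit.

The compounds shown leave open whether this exchange on the aromatic carbon changes growth inhibition at all, and by how much.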